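The source may report more compounds than this note shows. Statements on the series, on what has been measured and on what is new or still open speak of the compounds shown alone.

Measured in an ADME assay on HEK-293T cells (Homo sapiens) for cytotoxicity, read by luminescence, with a stated time of 24 h (a higher number here means that more compound is tolerated, a lower number that less compound is tolerated), all three values being limits:

- Compound 1 `COc1ccc(Cn2c(C(N)=O)cc3sccc32)cc1`: > 100000 nM
- Compound 2 `CCCNC(=O)c1cc2sccc2n1Cc1ccc(OC)cc1`: > 100000 nM
- Compound 3 `CCCNC(=O)C1CCN(C(=O)c2cc3sc(C(=O)c4ccccc4)cc3n2Cc2ccc(OC)cc2)CC1`: > 100000 nM

Compound 3 has no number in this assay, only the limit > 100000 nM. Within the data shown here, the series so far offers only (the limit of > 100000 nM in this assay, at which 3 of the 3 values shown sit), so no compound can be ranked against another.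

The next compound is compound 4 `CCCNC(=O)C1CCN(C(=O)c2cc3sc(CNCc4ccccc4)cc3n2Cc2ccc(OC)cc2)CC1`, with this change: (benzylamino)methyl in place of benzoyl on an aromatic carbon. In words, (benzylamino)methyl replaces benzoyl on an aromatic carbon, next to the ring sulfur.

Among the measured compounds shown here, the only measured step between close neighbours is a step that the two limits leave unreadable from compound 1 to compound 2. For the measured compounds named here, it concerns another place in the molecule and gives no size to carry over, and no measured compound tests a change at this carbon. The expectation is therefore weakly supported. Since compound 3 sits at the limit > 100000 nM, a readable result for compound 4 could only fall on the less tolerated side, and the limit may well be reported again. A small downward move is the working expectation, and no large one is indicated by the data. The expected step is an at least 1.4-fold lower number from compound 3 to compound 4 (0.15 log units; that floor lies within the scatter). For compound 4 the estimated value is 70000 nM, with an expected range of 20000 nM to 100000 nM.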

Compound 4, half-maximal cytotoxic concentration: 46800 nM
Compound 4: middle estimate off by 1.5-fold (0.17 log units), on the high side, within the range that was stated.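

In this assay, placing (benzylamino)methyl in place of benzoyl on the aromatic carbon next to the ring sulfur gives an at least 2.1-fold lower number from compound 3 to compound 4 (0.32 log units; beyond the scatter). Compound 4 gives 46800 nM, the only value in the series that is a number rather than a limit, and this carbon is the first place shown where a change produces a readable step. The step from compound 1 to compound 2 cannot be read, and compound 1, compound 2 and compound 3 each give only a limit of the assay: the limit of > 100000 nM in this assay, at which 3 of the 4 values shown sit.

The compounds shown leave open whether the lower number goes with the amine nitrogen, the benzyl group or the loss of the ketone carbonyl; an aminomethyl, a dimethylaminomethyl or a benzyloxymethyl group at this carbon would separate these parts. They also leave open how far the number falls with a longer chain between the amine nitrogen and the phenyl ring, and whether the same change gives a similar step when the propyl amide on the piperidine is replaced by a carboxylic acid.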